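The source may hold more compounds than are shown below. What is called first, only, known or untested is meant among the compounds shown, and "the series" means these compounds.

Measured compounds in a functional assay for inhibition, read by spectrophotometry, with a stated time of 30 min, tested at 1 uM; a higher number here means more inhibition at the concentration tested (going by the name of the read-out), a lower number less inhibition:
compound 2 `CC(C)CNC(=C\C(=O)/C=C/c1ccc(O)cc1)/C=C/c1ccc(O)cc1` gives 0.02%;
compound 1 `CCCNC(=C\C(=O)/C=C/c1ccc(O)c(OC)c1)/C=C/c1ccc(O)c(OC)c1` gives 0.1%;
compound 3 `COc1cc(/C=C/C(=O)/C=C(/C=C/c2ccc(O)c(OC)c2)NC2CCCCC2)ccc1O` gives 0.13%.

All three compounds share the same core and differ only in the group carried on the amine nitrogen. In this assay compound 2 sits with compounds 1 and 3 at near-zero inhibition, and its gap to each of them lies within the scatter of the assay, so no ranking among the three can be read from these numbers.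

The unmeasured compound 4 `CCC(C)NC(=C\C(=O)/C=C/c1ccc(O)cc1)/C=C/c1ccc(O)cc1` is reached from compound 2 by the change (sec-butyl in place of isobutyl on an amine nitrogen). For the measured compounds named here, one measured step bears on this kind of change: the exchange of one saturated carbon group for another on the amine nitrogen, cyclohexyl in place of propyl, which gave a number 0 percentage points higher from compound 1 to compound 3 (within the scatter). Going by the values given here, that step is within the scatter, and it is the only guide available here. A swap of isobutyl for sec-butyl on the same nitrogen is therefore expected to leave the read-out in this assay essentially unchanged, with no step beyond the scatter in either direction.

Compound 4 is thus expected to give 0.1% in this assay, in the range 0% to 8%. The corresponding expected step is a number 0.1 percentage points higher from compound 2 to compound 4 (within the scatter).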

Compound 4, a percentage reported as inhibition, at one concentration (the size of the read-out at that concentration, not a potency): 0.03%
Compound 4: the middle estimate sits 0.1 percentage points above what was measured; low and high end bracket the measured number.
By their numbers in this assay, from the lowest: compounds 2, 4, 1 and 3 (each within the scatter of the next).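

In this assay the exchange of isobutyl for sec-butyl on the amine nitrogen gives a number 0 percentage points higher from compound 2 to compound 4 (within the scatter), so the read-out does not separate these two groups. The earlier step on this nitrogen replaced a propyl chain with a cyclohexyl ring on the methoxy-bearing compounds, whereas this one keeps the same atoms and joins them differently, on compounds without that methoxy group. The result therefore extends the picture at this position: a rearrangement within a saturated four-carbon group, like the earlier exchange of chain for ring, leaves the number within the scatter and close to zero inhibition at the concentration tested. No measured finding offers an explanation for this result.

All the groups shown on this nitrogen are saturated carbon groups, so it remains open whether a benzyl group, or a chain ending in an amine or a carboxylic acid, would move the read-out beyond the scatter. For the compounds shown here, with every compound so far near zero, the read-out at this single concentration also leaves open whether the nitrogen substituent has any bearing on inhibition.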